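Oxygen to Sulfur Exchange on the Fluorophenyl Analogue

The compounds below may be only part of what the source reports. "The series", "measured", "known", "first", "only" and "open" are said of these compounds alone.

Compound 3 `Nc1cc(N)c2nc(-c3ccccc3)c(Oc3ccc(F)cc3)nc2c1` in a functional assay on LOX IMVI cells (Homo sapiens) for inhibition, read by sulforhodamine B assay, with a stated time of 48 h (a higher number here means a weaker inhibitor of growth, a lower number a stronger inhibitor of growth), is reported only as a limit, < 100000 nM, and not as a number. Its two relatives give numbers: compound 1 `Nc1cc(N)c2nc(-c3ccccc3)c(Oc3ccc(Cl)c(Cl)c3)nc2c1` gives 33900 nM, and compound 2 `Nc1cc(N)c2nc(-c3ccccc3)c(Sc3ccc(Cl)c(Cl)c3)nc2c1` gives 24500 nM. Compound 4 `Nc1cc(N)c2nc(-c3ccccc3)c(Sc3ccc(F)cc3)nc2c1` differs from compound 3 by (4-fluorophenyl)sulfanyl in place of 4-fluorophenoxy on an aromatic carbon. The same exchange has been measured once already, where a 1.4-fold lower number from compound 1 to compound 2 (0.14 log units; within the scatter). The steps leading to compound 3, a step that the limit leaves unreadable from compound 1 to compound 3 and a step that the limit leaves unreadable from compound 2 to compound 3, carry no readable size, since compound 3 sits at the limit of < 100000 nM in this assay, at which 1 of the 3 values shown sits. On this basis no step beyond the scatter is expected in this assay, so the expected change is a step that the limit leaves unreadable from compound 3 to compound 4. Compound 4 is therefore expected at 60000 nM, with a range from 20000 nM to 150000 nM.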

Compound 4, concentration for total growth inhibition: 40700 nM
Beside the measured number, compound 4's estimate is 1.5-fold (0.17 log units) above it, and the stated range covers the measured number.
By their numbers in this assay, from the lowest: compounds 2, 1 and 4 (each within the scatter of the next).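

On sulfur, the 4-fluorophenyl group now has a readable number in this assay, and the step from its 3,4-dichlorophenyl partner is a 1.7-fold higher number from compound 2 to compound 4 (0.22 log units; within the scatter). The step from the oxygen-linked 3,4-dichlorophenyl compound is a 1.2-fold higher number from compound 1 to compound 4 (0.08 log units; within the scatter), so swapping both the linking atom and the ring substituents leaves all three numbers within the scatter. The steps to and from compound 3 cannot be read because it is reported only as a limit: the limit of < 100000 nM in this assay, at which 1 of the 4 values shown sits.

From the compounds shown here alone, whether sulfur and oxygen differ with the 4-fluorophenyl group therefore stays open. Also open, going by these compounds, is how an amine or a carboxylic acid would behave at this position.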